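Aryl tail replaced by cyclohexylmethyl: compound 1 to compound 4

The source may report more compounds than this note shows. Statements on the series, on what has been measured and on what is new or still open speak of the compounds shown alone.

Measured so far in a functional assay on HEK293 cells for antagonist activity at P2X purinoceptor 7 (Homo sapiens), read by fluorescence, with a stated time of 2 h; a higher number here means a weaker inhibitor, a lower number a stronger inhibitor:
compound 1 `Cc1ccc(CCC(=O)NNc2c(Cl)cncc2Cl)cc1` gives 1400 nM
compound 2 `COc1ccc(CCC(=O)NNc2c(Cl)cncc2Cl)cc1` gives 1500 nM
compound 3 `O=C(NNc1c(Cl)cncc1Cl)C1CCc2ccccc2C1` gives 1100 nM

Compound 1 stands second highest of these three numbers; compound 2 lies a 1.1-fold higher number from compound 1 to compound 2 (0.03 log units; within the scatter) from it, and compound 3 also lies within the scatter of compound 1. Compound 4 `O=C(CCCC1CCCCC1)NNc1c(Cl)cncc1Cl` carries cyclohexylmethyl in place of 4-methylphenyl on a saturated chain carbon, two bonds along the chain from a carbonyl carbon. Among the measured compounds shown here, the one step measured on this tail, a 1.1-fold higher number from compound 1 to compound 2 (0.03 log units; within the scatter), alters a substituent on the retained aromatic ring rather than exchanging the ring; no measured pair removes the aromatic ring, and compound 3 adds nothing on that point beyond a number within the scatter. The expected step is therefore a 1.1-fold higher number from compound 1 to compound 4 (0.03 log units; within the scatter), nothing beyond the scatter, with a range widened for the untested change. Compound 4 is expected at 1500 nM, range 600 nM to 4000 nM.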

Compound 4, half-maximal inhibitory concentration: 360 nM
For compound 4 the middle estimate is 4.2-fold (0.62 log units) above the measured one; the whole stated range lies above it.
By their numbers in this assay, from the lowest: compound 4; then compounds 3, 1 and 2 (each within the scatter of the next).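

In this assay the exchange of 4-methylphenyl for cyclohexylmethyl gives a 3.9-fold lower number from compound 1 to compound 4 (0.59 log units; beyond the scatter), so an aromatic ring in the tail is not required at this position. The earlier step of a 1.1-fold higher number from compound 1 to compound 2 (0.03 log units; within the scatter) changed only a substituent on the retained aromatic ring, whereas this change of the ring itself moves the number beyond the scatter. Nothing measured here bears on the reason for this step.

Still open, on these data alone, is whether the tail needs a ring at all, which an open-chain alkyl tail would test. Also open, as far as these compounds go, is how a cyclopentyl ring, or an amine or hydroxyl on the cyclohexane ring, would compare with compound 4.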